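The source may report more compounds than this note shows. Statements on the series, on what has been measured and on what is new or still open speak of the compounds shown alone.

Working notes on the urea series. Of the compounds shown here, three share one core and have been measured in a physicochemical assay for solubility, at pH 7.4; a lower number here means a less soluble compound, a higher number a more soluble compound. Compound 1 `Cc1cc(NC(=O)Nc2ccccc2C(F)(F)F)c2ccccc2n1` gives 3800 nM. Compound 3 `Cc1cc(NC(=O)Nc2ccc(F)cc2)c2ccccc2n1` gives 3700 nM. Compound 2 `Cc1cc(NC(=O)Nc2cccc(C(N)=O)c2)c2ccccc2n1` gives 100 nM, the lowest of the three numbers: compound 3 stands a long way higher and compound 1 about as far again, both gaps well beyond the scatter. Compound 2 carries the carbamoyl on the aryl urea; compound 1 and compound 3 carry none, and both sit far above it in this assay.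

Compound 4 `COC(=O)c1cccc(NC(=O)Nc2cc(C)nc3ccccc23)c1` is not yet measured in this assay. It differs from compound 2 by methoxy in place of amino on a carbonyl carbon. For the measured compounds named here, no measured pair shows this change directly, so the expected size of the step rests only on where compound 2 stands against compound 1 and compound 3.

The step from compound 2 to compound 4 is expected to be upward, a 12-fold higher number from compound 2 to compound 4 (1.08 log units; beyond the scatter), since compound 2 with 100 nM lies far beneath compound 3 at 3700 nM. Compound 4 is accordingly estimated at 1200 nM, within a range of 250 nM to 6000 nM.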

Compound 4, solubility: 600 nM
Beside the measured number, compound 4's estimate is 2.0-fold (0.30 log units) above it, within the range that was stated.
By their numbers in this assay, from the lowest: compound 2; then compound 4; then compounds 3 and 1 (each within the scatter of the next).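

Methoxy in place of amino on a carbonyl carbon gives the first step read directly at this position in this assay, a 6.0-fold higher number from compound 2 to compound 4 (0.78 log units; beyond the scatter), so a change confined to this one group moves the number. The carbonyl and its aromatic carbon neighbour stay in place; the amino that leaves counts as a hydrogen-bond donor, and the methoxy that enters counts as a hydrogen-bond acceptor. No measurement here accounts for the step, so these counts remain a description of the change and not an explanation.

This single pair leaves open whether the step would hold on another aryl urea of the series. A carboxylic acid, a methylamino amide or a longer ester chain at the same carbonyl carbon would show whether the number follows the donor count or the particular group.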